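Swapping a Vinyl Arm for a Phenyl Ring

This account rests on a few compounds, and the source may have more. Where it says the series, first, only, none or still open, it means among the compounds named here.

Of the compounds shown here, three sharing one core have been measured for binding to the neuronal nicotinic receptor. Compound 1 `C#Cc1cncc(O[C@@H]2CCNC2)c1` carries an ethynyl group and gives 62 nM in an assay on a protein complex for binding affinity to Neuronal acetylcholine receptor; alpha4/beta2 (Rattus norvegicus); on this read-out lower numbers stand for stronger inhibition and higher numbers for weaker inhibition. Compound 2 `C=Cc1cncc(O[C@@H]2CCNC2)c1` carries a vinyl group in its place and gives 883 nM in this assay, the highest number of the three; its step of a 14-fold higher number from compound 1 to compound 2 (1.15 log units; beyond the scatter) is large. Compound 3 `C=Cc1cc(O[C@@H]2CCNC2)cnc1Cl` carries a chloro in place of hydrogen on an aromatic carbon; in this assay compound 3 gives 140 nM, a step of a 6.3-fold lower number from compound 2 to compound 3 (0.80 log units; beyond the scatter).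

Compound 4 `c1ccc(-c2cncc(O[C@@H]3CCNC3)c2)cc1` has not yet been measured. It differs from compound 2 in one place: phenyl in place of vinyl on an aromatic carbon. Among the measured compounds shown here, only the step from compound 1 to compound 2 concerns the same site, and it shows that what sits there can move this assay considerably; the step from compound 2 to compound 3 shows that a group can be added to the core of compound 2 without loss. For the measured compounds named here, no measured pair involves a phenyl here, so the direction rests on indirect evidence. Compound 4 is expected to bind somewhat more tightly than compound 2, a step of a 2.9-fold lower number from compound 2 to compound 4 (0.47 log units; beyond the scatter), with an estimated value of 300 nM and a likely range from 60 nM to 1500 nM.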

Compound 4, half-maximal inhibitory concentration: 1820 nM
Compound 4: middle estimate off by 6.1-fold (0.78 log units), on the low side; the whole stated range lies below it.
By their numbers in this assay, from the lowest: compound 1; then compound 3; then compound 2; then compound 4.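

Phenyl at this position, on an aromatic carbon two atoms from the ring nitrogen, does not recover what was lost on going from ethynyl to vinyl: this assay shows a 2.1-fold higher number from compound 2 to compound 4 (0.31 log units; beyond the scatter), and measured against the ethynyl group the change is a 29-fold higher number from compound 1 to compound 4 (1.47 log units; beyond the scatter). Across these three groups, ethynyl gives the lowest number and phenyl the highest, yet the move from vinyl to the much larger six-membered aromatic ring is only modest, while the move from ethynyl to vinyl, a 14-fold higher number from compound 1 to compound 2 (1.15 log units; beyond the scatter), is large. So size alone, counted in heavy atoms, does not track the change at this position, and no data shown here give a reason for the rise with phenyl.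

From the compounds shown here alone, it remains open whether an amine or a carboxylic acid on the phenyl ring would lower the number again, or whether a longer chain ending in an ethynyl group would keep the lower number of compound 1. Also open, going by these compounds, is whether the chloro that lowered the number of compound 2 would do the same for compound 4.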